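Compound 3 to compound 4: fluoro in place of methyl

This account rests on a few compounds, and the source may have more. Where it says the series, first, only, none or still open, it means among the compounds named here.

- compound 1 `Cc1cccc(Cl)c1CN1CCc2cc(-c3c(C)nc(C)c([C@H](OC(C)(C)C)C(=O)O)c3N3CCC(C)(C)CC3)ccc2C1`: 22500 nM
- compound 2 `Cc1cccc(F)c1CN1CCc2cc(-c3c(C)nc(C)c([C@H](OC(C)(C)C)C(=O)O)c3N3CCC(C)(C)CC3)ccc2C1`: >= 24000 nM (a limit of the assay)
- compound 3 `Cc1nc(C)c([C@H](OC(C)(C)C)C(=O)O)c(N2CCC(C)(C)CC2)c1-c1ccc2c(c1)CCN(Cc1cccc(F)c1C)C2`: >= 24000 nM (a limit of the assay)

In a toxicity assay on MT2 cells (Homo sapiens) for cytotoxicity (on this read-out higher numbers stand for lower toxicity in this test and lower numbers for higher toxicity in this test), compound 3 stands at >= 24000 nM. That value is a limit and not a number. The series runs up against (the limit of >= 24000 nM in this assay, at which 2 of the 3 values shown sit), and only compound 1 reads as a number.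

Compound 4 `Cc1nc(C)c([C@H](OC(C)(C)C)C(=O)O)c(N2CCC(C)(C)CC2)c1-c1ccc2c(c1)CCN(Cc1cccc(F)c1F)C2` differs from compound 3 by fluoro in place of methyl on an aromatic carbon, ortho to a fluoro group and ortho to a large group: fluoro in place of methyl on an aromatic carbon. The same difference reads as 3-fluoro-2-methylbenzyl to 2,3-difluorobenzyl.

Going by the values given here, no measured step makes this exact swap. The nearest evidence lies on the same benzyl group. Fluoro in place of chloro gave an at least 1.0-fold higher number from compound 1 to compound 2 (0.02 log units; that floor lies within the scatter). The change from 2-chloro-6-methylphenyl to 3-fluoro-2-methylphenyl gave an at least 1.0-fold higher number from compound 1 to compound 3 (0.02 log units; that floor lies within the scatter). The remaining comparison is a step that the two limits leave unreadable from compound 2 to compound 3, which adds no size.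

Neither readable floor exceeds the scatter, so no step beyond the scatter is expected in this assay, and no direction is favoured. The estimated step is a number no higher from compound 3 to compound 4 (the limit leaves the size open). For compound 4 the estimate is 24000 nM, with an expected range of 14000 nM to 40000 nM.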

Compound 4, half-maximal cytotoxic concentration: >= 24000 nM
Compound 4: a limit, no number (the forecaster's own chance of this, stated with the estimate: 70%); the middle value sits exactly at the limit.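

In this assay compound 4 gives >= 24000 nM, which is a limit of the assay and not a number. At this aromatic carbon, ortho to a fluoro group and ortho to a large group, fluoro in place of methyl gives a benzyl group with no methyl that still reads as a limit, but the steps to compound 4 from compound 2 and from compound 3 cannot be read, as both ends of each are limits. The only readable step is an at least 1.0-fold higher number from compound 1 to compound 4 (0.02 log units; that floor lies within the scatter), and the series now sits mostly at one boundary: the limit of >= 24000 nM in this assay, at which 3 of the 4 values shown sit.

Going by these compounds, how far compounds 2, 3 and 4 lie past that limit stays open, so any difference among the three benzyl groups remains hidden in this read-out. Also open, on these data alone, is whether a different group on this aromatic carbon, such as an amine, a methoxy group or a trifluoromethyl group, would give a readable number in this assay.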